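Removing the Acyl Group From Compound 3

The source may report more compounds than this note shows. Statements on the series, on what has been measured and on what is new or still open speak of the compounds shown alone.

Going by the values given here, compound 3 `O=C(Nc1nn(-c2ccccc2)c(=O)c2ccccc12)c1ccc(Cl)cc1` stands at the top of the three numbers known so far in an assay on CHO cells for displacement of a labelled ligand from adenosine receptor A1 (Homo sapiens), tested at 10 uM (a higher number here means more inhibition at the concentration tested (going by the name of the read-out), a lower number less inhibition), where compound 3 gives 26%. Compound 1 `O=C(Nc1ccc(Cl)cc1)Nc1nn(-c2ccccc2)c(=O)c2ccccc12` sits closest, with compound 1 giving 10% in this assay, while compound 2 `COc1ccc(NC(=O)Nc2nn(-c3ccccc3)c(=O)c3ccccc23)cc1` is furthest away, with compound 2 giving 4%. The two measured steps that lead to compound 3 were a number 16 percentage points higher from compound 1 to compound 3 (beyond the scatter) and a number 22 percentage points higher from compound 2 to compound 3 (beyond the scatter); both swap the group attached to the carbonyl carbon while keeping the carbonyl in place.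

Compound 4 `Nc1nn(-c2ccccc2)c(=O)c2ccccc12` is not yet measured. Its change from compound 3 is hydrogen in place of (4-chlorophenyl)carbonyl on a nitrogen on an aromatic ring. Among the compounds with values here, no measured step removes the whole carbonyl-bearing group, so no step bears directly on this change. What the numbers do show is that the two compounds carrying an amino group on that carbonyl carbon sit lower than compound 3, and that compound 3 is the only one with the (4-chlorophenyl)carbonyl group; taking that group away entirely is expected to move the number downward by a modest amount, though the direction rests on this indirect evidence only. Compound 4 is therefore estimated to give 8% in this assay, within a range from 0% to 25%, which means a step of a number 18 percentage points lower from compound 3 to compound 4 (beyond the scatter).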

Compound 4, a percentage reported as inhibition, at one concentration (the size of the read-out at that concentration, not a potency): 24%
Beside the measured number, compound 4's estimate is 16 percentage points below it; the measured number falls inside the stated range.
By their numbers in this assay, from the lowest: compounds 2 and 1 (each within the scatter of the next); then compounds 4 and 3 (each within the scatter of the next).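

In this assay, the whole (4-chlorophenyl)carbonyl group on a nitrogen on an aromatic ring can be replaced by a single hydrogen with only a number 2 percentage points lower from compound 3 to compound 4 (within the scatter), so that group, aromatic ring included, is not needed to reach the number seen for compound 3. Going by these compounds alone, this changes how the earlier steps read: compound 3 no longer stands alone at the top, and the printed values show compound 4 with 24%, compound 1 with 10% and compound 2 with 4%, which points the question towards the two compounds with an arylamino group on the carbonyl carbon rather than towards what the (4-chlorophenyl)carbonyl group adds. Nothing measured here explains why the number stays in place when the group leaves.

The compounds shown leave open whether a small acetyl group or a plain methyl on that nitrogen would behave like the hydrogen or like the larger groups. They also leave open whether an amine or a carboxylic acid placed elsewhere on the shared core would move the number at all, and a reading at one concentration gives no potency for any of these compounds.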